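The source may report more compounds than this note shows. Statements on the series, on what has been measured and on what is new or still open speak of the compounds shown alone.

In an ADME assay on BJ cells (Homo sapiens), read by MTT assay, with a stated time of 72 h (on this read-out lower numbers stand for stronger inhibition and higher numbers for weaker inhibition), compound 2 (`COc1nc(N)nc2c1c(-c1ccoc1)cn2[C@@H]1O[C@H](CO)[C@@H](O)[C@H]1O`) gives > 100000 nM as a limit of the assay, not as a number. Compound 1 (`Nc1nc(N)c2c(-c3ccsc3)cn([C@@H]3O[C@H](CO)[C@@H](O)[C@H]3O)c2n1`) gives > 100000 nM as a limit too. Going by the values given here, the series so far therefore offers only the limit of > 100000 nM in this assay, at which 2 of the 2 values shown sit, and no rank order of compound 2 against compound 1.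

Compound 3 (`COc1nc(N)nc2c1c(-c1ccsc1)cn2[C@@H]1O[C@H](CO)[C@@H](O)[C@H]1O`) carries thiophen-3-yl in place of furan-3-yl on an aromatic carbon of a five-membered aromatic ring with 1 nitrogen (thiophen-3-yl in place of furan-3-yl on an aromatic carbon), and the rest of compound 2 stays as it is. Among the compounds with values here, no measured pair shows this exchange, so the expectation rests on compound 2 alone, whose > 100000 nM remains a limit. No shift beyond the scatter is expected in this assay in either direction, and another limit is the likeliest report. The expected move is a number no higher from compound 2 to compound 3 (the limit leaves the size open) on this estimate. The estimate for compound 3 is 100000 nM with an expected range from 50000 nM to 200000 nM in this read-out.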

Compound 3, half-maximal inhibitory concentration: > 100000 nM
Compound 3 gave a limit, no number; the forecaster's own chance of this, stated with the estimate: 80%; the middle value lies on the limit itself.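

In this assay compound 3 gives > 100000 nM, a limit and not a number. Going by these compounds alone, no step from compound 1 or compound 2 to compound 3 can be read, as every value is a limit: the limit of > 100000 nM in this assay, at which 3 of the 3 values shown sit. The compounds shown leave open whether compound 1, compound 2 and compound 3 differ at all in this assay.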